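Three Sugar-Like Compounds at the Limit, and One More

The source may report more compounds than this note shows. Statements on the series, on what has been measured and on what is new or still open speak of the compounds shown alone.

Measured in a functional assay on HeLa cells (Homo sapiens) for antiproliferative activity, read by sulforhodamine B assay; a lower number here means a stronger inhibitor of growth, a higher number a weaker inhibitor of growth:
- Compound 1 `CCC[C@@H]1O[C@H](CO)[C@@H](O)[C@H](O)[C@H]1O` gives > 50000 nM
- Compound 2 `CC(=O)OC[C@H]1O[C@@H](Cc2ccccc2)[C@H](OC(C)=O)[C@@H](OCc2ccccc2)[C@@H]1OC(C)=O` gives > 50000 nM
- Compound 3 `CC(=O)O[C@@H]1[C@@H](OC(C)=O)[C@H](Cc2ccccc2)O[C@H](COCc2ccccc2)[C@H]1OC(C)=O` gives > 50000 nM

Each of these three values is a limit of the assay and not a number. Compound 3 stands at the limit of > 50000 nM in this assay, at which 3 of the 3 values shown sit, so it cannot be ranked against compound 1 or compound 2.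

Compound 4 `CC(=O)O[C@@H]1[C@@H](OCc2ccccc2)[C@H](OC(C)=O)[C@@H](COCc2ccccc2)O[C@H]1Cc1ccccc1` differs from compound 3 in one place, with benzyl in place of acetyl on an oxygen on a saturated carbon. The same difference reads acetoxy to benzyloxy. Within the data shown here, no measured pair shows what such a change does, and the three limits give no numerical starting point. In this assay, the expectation is therefore no change beyond the scatter, with a modest strengthening possible and a limit result again the likeliest outcome. The expected step is an at least 1.1-fold lower number from compound 3 to compound 4 (0.04 log units; that floor lies within the scatter). For compound 4 the estimated value is 45000 nM, with an expected range from 15000 nM to 100000 nM.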

Compound 4, concentration for 50% growth inhibition: 5400 nM
For compound 4 the middle estimate is 8.3-fold (0.92 log units) above the measured one, and the stated range ends above it.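

In this assay, benzyl in place of acetyl on an oxygen on a saturated carbon turns a compound at the limit into one with a measured value, giving an at least 9.2-fold lower number from compound 3 to compound 4 (0.96 log units; beyond the scatter) and, read from the other starting compound, an at least 9.2-fold lower number from compound 2 to compound 4 (0.96 log units; beyond the scatter) as well. Among these compounds, both steps are floors, not exact sizes, and both lie beyond the scatter, so this change can matter here even though the earlier compounds showed no difference that could be read. Compound 4 is the only one of the four that is not held at that limit: the limit of > 50000 nM in this assay, at which 3 of the 4 values shown sit.

What the compounds shown leave open is whether benzyl itself is needed, or whether a methyl, a longer chain or an amine on the same oxygen would do the same. Also open, from the compounds shown here alone, is whether a benzyl ring carrying fluorine or methoxy would move the value further in either direction.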